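Adding a Methyl to the Phenyl of Compound 2

The compounds below may be only part of what the source reports. "The series", "measured", "known", "first", "only" and "open" are said of these compounds alone.

In a functional assay on DU-145 cells (Homo sapiens) for antiproliferative activity, read by MTT assay (on this read-out higher numbers stand for weaker inhibition and lower numbers for stronger inhibition), compound 1 `Cc1nn2c(-c3nc4cc(Cl)c(Cl)cc4[nH]3)c(-c3ccccc3)nc2s1` gives 19100 nM. Compound 2 `Cc1nn2c(-c3nc4cc(Cl)c(F)cc4[nH]3)c(-c3ccccc3)nc2s1` gives > 30000 nM, which is a limit and not a number. Compound 3 `Cc1ccc(-c2nc3sc(C)nn3c2-c2nc3cc(Cl)c(F)cc3[nH]2)cc1` differs from compound 2 by methyl in place of hydrogen on an aromatic carbon, phenyl to 4-methylphenyl. Within the data shown here, the only measured step, fluoro in place of chloro, is an at least 1.5-fold higher number from compound 1 to compound 2 (0.19 log units; that floor lies within the scatter), and it concerns a different group, so it bears on this change only loosely. No shift beyond the scatter is therefore expected in this assay. The expected step is a number no higher from compound 2 to compound 3 (the limit leaves the size open). For compound 3 the estimated value is 30000 nM, with an expected range of 12000 nM to 60000 nM.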

Compound 3, half-maximal inhibitory concentration: 11800 nM
Beside the measured number, compound 3's estimate is 2.5-fold (0.41 log units) above it; the whole stated range lies above it.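

In this assay, methyl in place of hydrogen on the phenyl gives an at least 2.5-fold lower number from compound 2 to compound 3 (0.40 log units; beyond the scatter), so this ring, unchanged between compound 1 and compound 2, is a place where one added carbon moves the number beyond the scatter. As far as these compounds go, compound 2 has only a limit and not a number, so the step's full size stays unknown: the limit of > 30000 nM in this assay, at which 1 of the 3 values shown sits. From the compounds shown here alone, it remains open whether an amine or a carboxylic acid at this place would move the number in the same direction, and whether the methyl step would hold with chloro in place of the fluoro.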